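The compounds below may be only part of what the source reports. "The series", "measured", "known", "first", "only" and "open" are said of these compounds alone.

Working notes on the series, followed in a functional assay on HBL-100 cells (Homo sapiens) for antiproliferative activity, read by sulforhodamine B assay, with a stated time of 48 h; a lower number here means a stronger inhibitor of growth, a higher number a weaker inhibitor of growth. Compound 3 (`CCCC(C#CC(=O)OC)O/C=C/C(=O)OC`) stands lowest of the three measured compounds at 270 nM with the steps to it from both others beyond the scatter. On the same core, compound 1 (`CCCCCC(C#CC(=O)OC)O/C=C/C(=O)OC`) gives 1900 nM and compound 2 (`CCCCCCC(C#CC(=O)OC)O/C=C/C(=O)OC`) gives 2500 nM as its reading. Compound 4 (`COC(=O)C#CC(C[C@@H](C)CCC=C(C)C)O/C=C/C(=O)OC`) is not yet measured. Its difference from compound 3 is 4-methylpent-3-en-1-yl in place of hydrogen on a saturated chain carbon bound to two saturated chain carbons with 4-methylpent-3-en-1-yl in place of hydrogen on a saturated chain carbon bound to two saturated chain carbons.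

Among the compounds with values here, two measured steps bear on this change, both of them modest (a 7.0-fold lower number from compound 1 to compound 3 (0.85 log units; beyond the scatter)) and (a 9.3-fold lower number from compound 2 to compound 3 (0.97 log units; beyond the scatter)). Read in reverse, more saturated chain on compound 3 goes with a higher number. The remaining step (a 1.3-fold higher number from compound 1 to compound 2 (0.12 log units; within the scatter)) shows no further rise, so the effect of chain growth does not continue steadily across these three compounds. Within the data shown here, no measured compound carries a branch or a double bond in this chain, which leaves the estimate wide. A higher number is therefore expected, of about the size of the two modest steps (an 8.5-fold higher number from compound 3 to compound 4 (0.93 log units; beyond the scatter)). For compound 4 the estimated value is 2300 nM with an expected range from 800 nM to 7000 nM at the upper end.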

Compound 4, concentration for 50% growth inhibition: 3100 nM
Estimate against measurement, compound 4: 1.3-fold (0.13 log units) below; the measured number falls inside the stated range.
By their numbers in this assay, from the lowest: compound 3; then compounds 1, 2 and 4 (each within the scatter of the next).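

In this assay, within the data shown here, 4-methylpent-3-en-1-yl in place of hydrogen on a saturated chain carbon bound to two saturated chain carbons brings an 11-fold higher number from compound 3 to compound 4 (1.06 log units; beyond the scatter), the one step graded large. Among these compounds, compound 4 is the first measured compound with a branch and a double bond in this chain, and this chain does not bring the number back towards that of compound 3, which remains the lowest of the four, while compounds 1, 2 and 4 stand each within the scatter of the next. The data shown offer no explanation for this step.

The branch, the double bond and the added chain length enter together in compound 4, so their separate contributions to the step remain unresolved, and an unbranched saturated chain of matching length on the shared core would be needed to begin to separate them. Also open, going by these compounds, is whether a chain ending in a carboxylic acid or an amine would follow the same trend or return the number towards that of compound 3.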